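Swapping the aryl group on the triazole of compound 1

The compounds below may be only part of what the source reports. "The series", "measured", "known", "first", "only" and "open" are said of these compounds alone.

Measured in a functional assay on MCF7 cells (Homo sapiens) for inhibition, read by sulforhodamine B assay, with a stated time of 48 h, tested at 50 uM; on this read-out lower numbers stand for less inhibition of growth and higher numbers for more inhibition of growth at the one concentration tested:
compound 1 `COc1ccc([C@@H]2C/C(=N/OCc3cn(-c4ccc(O)cc4)nn3)c3cc(CC=C(C)C)c(OC)cc3O2)cc1` gives 63%
compound 2 `COc1cc2c(cc1CC1OC1(C)C)C(=O)C[C@@H](c1ccc(O)cc1)O2` gives 98%
compound 3 `COc1cc2c(cc1CC=C(C)C)[C@H](O)C[C@@H](c1ccc(O)cc1)O2` gives 49%

Compound 1 stands second of these three numbers. Compound 3 (49%) lies below compound 1, and compound 2 (98%) lies above it, with both gaps beyond the usual scatter.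

The next compound to be tested is compound 4 `COc1ccc([C@@H]2C/C(=N/OCc3cn(-c4ccccc4CO)nn3)c3cc(CC=C(C)C)c(OC)cc3O2)cc1`, which keeps the core of compound 1 and differs in one place. It carries 2-(hydroxymethyl)phenyl in place of 4-hydroxyphenyl on an aromatic nitrogen.

Among the measured compounds shown here, no two measured compounds differ in one place only, so the data give no direct guide to the size of this step in this assay. For the measured compounds named here, compound 1 (63%) is the only measured compound with the five-membered aromatic ring with 3 nitrogen, and it is therefore the natural starting point for the expectation. With no evidence for a direction, no change beyond the scatter is expected. The estimated change is a number 3 percentage points lower from compound 1 to compound 4 (within the scatter), which is a small one. For compound 4 the expected value is 60%, with an estimated range from 38% to 82%.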

Compound 4, percent growth inhibition at one concentration: 100%
Estimate against measurement, compound 4: 40 percentage points below; the measured number lies above the stated range.
By their numbers in this assay, from the lowest: compound 3; then compound 1; then compounds 2 and 4 (each within the scatter of the next).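

In this assay, putting 2-(hydroxymethyl)phenyl in place of 4-hydroxyphenyl on the aromatic nitrogen of the five-membered aromatic ring with 3 nitrogen gives a number 37 percentage points higher from compound 1 to compound 4 (beyond the scatter). Among the compounds shown here, this is the first direct reading of any single change, and it shows that growth inhibition at the one concentration tested responds strongly to the aryl group at this position. The step occurs although both groups have one six-membered aromatic ring of carbon only, 1 hydrogen-bond donor and 1 hydrogen-bond acceptor, and no evidence is available to explain it.

The change alters both the hydroxyl-bearing group and its place on the phenyl ring, so the compounds shown cannot separate these two features, and 2-hydroxyphenyl and 4-(hydroxymethyl)phenyl would be needed to tell them apart. As far as these compounds go, whether the hydroxyl itself matters also remains open, a question that 2-(aminomethyl)phenyl or 2-(methoxymethyl)phenyl at the same position could address.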